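This account rests on a few compounds, and the source may have more. Where it says the series, first, only, none or still open, it means among the compounds named here.

Measured compounds:
compound 1, `CCCCS(=O)(=O)NNC(=O)[C@@H](NC(=O)c1cccc(Cn2ccnc2)c1)[C@@H](C)CC`, an assay on HEK293 cells for displacement of a labelled ligand from Type-2 angiotensin II receptor (Homo sapiens), tested at 10 uM; on this read-out higher numbers stand for a stronger effect at the one concentration tested and lower numbers for a weaker effect: "not determined" (no result reported)
compound 2, `CCCCS(=O)(=O)NC(=O)[C@@H](NC(=O)c1cccc(Cn2ccnc2)c1)[C@@H](C)CC`, in this assay: "not determined" (no result reported)
compound 3, `CC[C@H](C)[C@H](NC(=O)c1cccc(Cn2ccnc2)c1)C(=O)NS(=O)(=O)c1ccccc1`, in this assay: 24%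

For the measured compounds named here, compound 1 stands without a number in this assay, and the same is true of compound 2, so no step between measured compounds can be read off here. The only figure recorded is that of compound 3, which in this assay gives 24%.

Compound 4, `CC[C@H](C)[C@H](NC(=O)c1cccc(Cn2ccnc2)c1)C(=O)NNS(=O)(=O)c1c(C)cc(C)cc1C`, follows from compound 1 by one change: 2,4,6-trimethylphenyl in place of butyl on a sulfonyl sulfur. Nothing measured shows how this exchange on the sulfonyl sulfur plays out, since compound 1 itself carries no number. What can be said is that compound 3, which also carries an aromatic ring on its sulfonyl sulfur, sits at a modest level in this assay, and compound 4 shares that feature. No step beyond the usual scatter is expected from compound 1 to compound 4; the expectation is simply a modest read-out of the same order as that of compound 3.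

Compound 4 is therefore estimated to give 25% in this assay, with a range from 5% to 50%.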

Compound 4, a percentage reported as inhibition, at one concentration (the size of the read-out at that concentration, not a potency): 27%
The estimate for compound 4 lay 2 percentage points below the measured number, and the stated range covers the measured number.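

No step can be read between compound 1 and compound 4, as compound 1 has no single number in this assay here. Going by these compounds, what exchanging butyl for 2,4,6-trimethylphenyl on the sulfonyl sulfur does to this read-out stays open. No further evidence bears on the result.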